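This account rests on a few compounds, and the source may have more. Where it says the series, first, only, none or still open, it means among the compounds named here.

Compound 2, `Cn1ncnc1-c1cc(Oc2ccc(NC(=O)N/N=C/c3ccccc3)cc2F)ccn1`, gives the highest number of the two measured values in a functional assay on NCI-H460 cells (Homo sapiens) for cytotoxicity, read by MTT assay, with a stated time of 72 h (on this read-out lower numbers stand for stronger inhibition and higher numbers for weaker inhibition), namely 52200 nM. Compound 1, `COc1ccc(/C=N/NC(=O)Nc2ccc(Oc3ccnc(-c4nncn4CCN(C)C)c3)c(F)c2)c(OC)c1`, gives 1570 nM in this assay, a markedly lower number that lies beyond the usual scatter; compound 1 differs from compound 2 in several places, however, so its value does not isolate any single change. Compound 3, `Cn1cnnc1-c1cc(Oc2ccc(NC(=O)N/N=C/c3ccccc3)cc2F)ccn1`, has not yet been measured. It differs from compound 2 in one place: 4-methyl-4H-1,2,4-triazol-3-yl in place of 1-methyl-1H-1,2,4-triazol-5-yl on an aromatic carbon. Among the measured compounds shown here, no measured pair differs only in this way, so the size of the step rests on judgement. For compound 3 the step is expected to come out as a 2.1-fold lower number from compound 2 to compound 3 (0.32 log units; beyond the scatter), leaning toward a lower number but not clearly beyond the scatter. Compound 3 is therefore estimated at 25000 nM, with a range from 6000 nM to 80000 nM.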

Compound 3, half-maximal inhibitory concentration: 15700 nM
For compound 3 the middle estimate is 1.6-fold (0.20 log units) above the measured one; the measured number falls inside the stated range.
By their numbers in this assay, from the lowest: compound 1; then compound 3; then compound 2.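

At this place, on an aromatic carbon next to the ring nitrogen, the two triazolyl groups have the same heavy atoms and the same counts of hydrogen-bond donors and acceptors, so only the way those atoms are joined separates them. Even so, this assay records a 3.3-fold lower number from compound 2 to compound 3 (0.52 log units; beyond the scatter), which shows that the read-out responds to this rearrangement alone, a modest step that the earlier compounds could not isolate. Nothing shown here explains why the two groups differ.

The compounds shown leave open how an imidazole, a carboxylic acid or an unsubstituted 1,2,4-triazole would read at this place in this assay. They also leave open whether the same step would appear on the core of compound 1, which differs from compound 2 in several places.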